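The source may hold more compounds than are shown below. What is called first, only, known or untested is meant among the compounds shown, and "the series" means these compounds.

Measured so far in a functional assay on SJSA-1 cells (Homo sapiens) for inhibition, read by CCK-8 assay, with a stated time of 72 h, tested at 1 uM; on this read-out lower numbers stand for less inhibition and higher numbers for more inhibition at the one concentration tested (going by the name of the read-out):

- compound 1, `COc1ccccc1N1C(=O)C(C)SC1c1cccc(C(=O)NCCCCc2ccccc2)c1` — compound 1 gives 84%
- compound 2, `COc1ccccc1N1C(=O)CSC1c1cc(F)cc(C(=O)O)c1` — compound 2 gives 0%
- compound 3, `COc1ccc(OC)c(N2C(=O)CSC2c2cccc(C(=O)NCCCCc3ccccc3)c2)c1` — compound 3 gives 48%

Compound 3 stands second highest of the three numbers in this assay. Its nearest neighbour is compound 1, whose number lies higher by a gap beyond the scatter; the furthest is compound 2, whose number lies lower by a gap beyond the scatter. Compound 2 also lacks the amide chain that compounds 1 and 3 share, so its value says little about the change followed here.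

The next compound, compound 4, `O=C(NCCCCc1ccccc1)c1cccc(C2SCC(=O)N2c2cccc(F)c2)c1`, differs from compound 3 in one place: 3-fluorophenyl in place of 2,5-dimethoxyphenyl on an amide-type nitrogen in a ring. Among the measured compounds shown here, no step of this kind has been measured, so the size of the change in this assay cannot be read off a precedent. The amide chain of compound 3 is kept in compound 4, and the lowest number in the series belongs to compound 2, which does not carry it. The expectation is a small rise in this assay, of about a number 7 percentage points higher from compound 3 to compound 4 (within the scatter), which may not exceed the usual scatter. Compound 4 is therefore estimated at 55%, with a range from 20% to 85%.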

Compound 4, a percentage reported as inhibition, at one concentration (the size of the read-out at that concentration, not a potency): 80%
Compound 4: middle estimate off by 25 percentage points, on the low side; low and high end bracket the measured number.
By their numbers in this assay, from the lowest: compound 2; then compound 3; then compounds 4 and 1 (each within the scatter of the next).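

On the amide-type nitrogen in the ring, the choice of aryl group matters: in this assay, putting 3-fluorophenyl in place of 2,5-dimethoxyphenyl gives a number 32 percentage points higher from compound 3 to compound 4 (beyond the scatter), with the amide chain and the rest of the core unchanged. The entering group has fewer heavy atoms and no hydrogen-bond acceptors, but this single step cannot separate the loss of the two methoxy groups from the gain of fluorine. Nothing available accounts for the size of the step.

Still open, going by these compounds, is how a plain phenyl, a 3-chlorophenyl or a pyridyl ring would read on this nitrogen, which would show whether fluorine itself contributes to the step. Also open, on these data alone, is whether the same exchange gives a step of similar size when the amide carries a shorter chain.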